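The source may hold more compounds than are shown below. What is called first, only, known or untested is meant among the compounds shown, and "the series" means these compounds.

Working notes on the series: in a functional assay on HL-60 cells (Homo sapiens) for antiproliferative activity, with a stated time of 72 h (a lower number here means a stronger inhibitor, a higher number a weaker inhibitor), compound 1 `OC[C@H]1O[C@@H](n2cnc3c(NCc4ccccc4F)ncnc32)[C@H](O)[C@@H]1O` gives 3200 nM, compound 2 `COc1cccc(CNc2ncnc3c2ncn3[C@@H]2O[C@H](CO)[C@@H](O)[C@H]2O)c1` gives 4900 nM and compound 3 `OC[C@H]1O[C@@H](n2cnc3c(NCc4ccc(Cl)c(Cl)c4)ncnc32)[C@H](O)[C@@H]1O` gives 2000 nM. The standing of compound 3 rests on two steps. One lies beyond the scatter, a 2.5-fold lower number from compound 2 to compound 3 (0.39 log units; beyond the scatter), and the other within it, a 1.6-fold lower number from compound 1 to compound 3 (0.20 log units; within the scatter). The structural change to compound 4 `COc1cc(CNc2ncnc3c2ncn3[C@@H]2O[C@H](CO)[C@@H](O)[C@H]2O)cc(OC)c1`, not yet measured, is 3,5-dimethoxyphenyl in place of 3,4-dichlorophenyl on a saturated chain carbon bound to a nitrogen on an aromatic ring, on a saturated chain carbon bound to a nitrogen on an aromatic ring.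

Within the data shown here, the closest precedent is compound 2, the only measured member with a methoxy group, and its step is a 2.5-fold lower number from compound 2 to compound 3 (0.39 log units; beyond the scatter). Read in reverse, that step suggests a modest rise in this assay on going from 3,4-dichlorophenyl to 3,5-dimethoxyphenyl. The remaining step, a 1.5-fold higher number from compound 1 to compound 2 (0.19 log units; within the scatter), stays within the scatter, so the aryl exchanges seen so far are small. Among the measured compounds shown here, no measured compound carries 3,5-dimethoxyphenyl, which leaves the effect of the added methoxy group open and the range wide. The expected step is a 2.4-fold higher number from compound 3 to compound 4 (0.38 log units; beyond the scatter). Compound 4 is estimated at 4800 nM, with an expected range of 2300 nM to 10000 nM.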

Compound 4, half-maximal inhibitory concentration: 20200 nM
Beside the measured number, compound 4's estimate is 4.2-fold (0.62 log units) below it; measured number above the stated range.
By their numbers in this assay, from the lowest: compounds 3, 1 and 2 (each within the scatter of the next, the first and the last beyond it); then compound 4.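

In this assay, adding methoxy in place of hydrogen on an aromatic carbon gives a 4.1-fold higher number from compound 2 to compound 4 (0.62 log units; beyond the scatter) and is a wider step than any among the three earlier compounds, so a single methoxy and the 3,5-dimethoxyphenyl group do not read as equivalent at this position. The exchange of the 3,4-dichlorophenyl group gives a 10-fold higher number from compound 3 to compound 4 (1.00 log units; beyond the scatter) and the exchange of the 2-fluorophenyl group gives a 6.3-fold higher number from compound 1 to compound 4 (0.80 log units; beyond the scatter), which sets compound 4 apart from all three earlier members. The aryl group on a saturated chain carbon bound to a nitrogen on an aromatic ring therefore matters more than the earlier steps suggested, although the shift shown here is only towards a higher number, with no member yet below compound 3.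

No data on hand give a reason for this rise. As far as these compounds go, it remains open whether a hydroxy group or an amine in place of the methoxy groups, or a 3,5-dichlorophenyl group, would stay with compound 4 or return to the range of the three earlier compounds.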